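Restoring the Secondary Amine and Halogen on the Benzyl Arm

This account rests on a few compounds, and the source may have more. Where it says the series, first, only, none or still open, it means among the compounds named here.

Compound 3 `CN(CCCNS(=O)(=O)c1cc(C(F)(F)F)cc(C(F)(F)F)c1)Cc1ccccc1` gives 28000 nM in a functional assay on A2780 cells (Homo sapiens) for inhibition, read by MTT assay, with a stated time of 72 h (a higher number here means a weaker inhibitor of growth, a lower number a stronger inhibitor of growth), the highest number among the three compounds measured. Compound 1 `O=S(=O)(NCCNCc1ccc(-c2ccccc2)cc1)c1cc(C(F)(F)F)cc(C(F)(F)F)c1` gives 2600 nM in this assay, and compound 2 `O=S(=O)(NCCCCNCc1ccc(Br)cc1)c1cc(C(F)(F)F)cc(C(F)(F)F)c1` gives 2100 nM. For the measured compounds named here, the one step that bears on the present change is a 13-fold higher number from compound 2 to compound 3 (1.12 log units; beyond the scatter), which came with benzyl(methyl)amino in place of ((4-bromobenzyl)amino)methyl. Compound 4 `O=S(=O)(NCCCNCc1ccc(Cl)cc1)c1cc(C(F)(F)F)cc(C(F)(F)F)c1` carries (4-chlorobenzyl)amino in place of benzyl(methyl)amino on a saturated chain carbon, three bonds along the chain from a sulfonamide nitrogen, which largely reverses that change. Because a 13-fold higher number from compound 2 to compound 3 (1.12 log units; beyond the scatter) was large, a step of similar size in the downward direction, beyond the scatter, is expected here. Compound 4 is therefore expected to give 3000 nM, between 1000 nM and 9000 nM. The expected step is a 9.3-fold lower number from compound 3 to compound 4 (0.97 log units; beyond the scatter).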

Compound 4, concentration for 50% growth inhibition: 1800 nM
Compound 4: the middle estimate sits 1.7-fold (0.22 log units) above what was measured; the range from low to high includes it.
By their numbers in this assay, from the lowest: compounds 4, 2 and 1 (each within the scatter of the next); then compound 3.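

Placing (4-chlorobenzyl)amino on this chain carbon brings a 16-fold lower number from compound 3 to compound 4 (1.19 log units; beyond the scatter), so the chain of compound 3 does not by itself fix its high number. Set against the longer chain and bromine of compound 2, there is only a 1.2-fold lower number from compound 2 to compound 4 (0.07 log units; within the scatter), so these two differences taken together leave no clear change. Nothing measured here explains either step.

The larger step joins two changes, the loss of the nitrogen's methyl and the gain of chlorine, and their shares remain unseparated. Going by these compounds, how a fluorine or a methoxy group on the benzyl ring would compare remains open.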